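This account rests on a few compounds, and the source may have more. Where it says the series, first, only, none or still open, it means among the compounds named here.

Measured compounds:
- compound 1, `Cc1ccccc1N1CCN(C(=O)CN2C(=O)CC(C)C2=O)CC1`: in a functional assay on the whole organism (strain CD1) with Mus musculus as the target, in the maximal electroshock model, with a stated time of 0.5 h (on this read-out lower numbers stand for an effect already at smaller amounts and higher numbers for an effect only at larger amounts of compound), compound 1 gives 300 mg/kg
- compound 2, `CCC1(C)CC(=O)N(CC(=O)N2CCN(c3ccccc3C)CC2)C1=O`: in this assay compound 2 gives 100 mg/kg
- compound 3, `CC1CC(=O)N(CC(=O)N2CCN(c3ccccc3F)CC2)C1=O`: in this assay compound 3 gives 300 mg/kg

Compound 2 holds the lowest number of the three, the only one beyond the scatter of the others. Adding an ethyl to a saturated ring carbon of compound 1 gives a 3.0-fold lower number from compound 1 to compound 2 (0.48 log units; beyond the scatter), while compound 3 shows the same number as compound 1, so compound 2 stands the same distance below both.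

Compound 4, `CCC1(C)CC(=O)N(CC(=O)N2CCN(c3ccc(F)cc3)CC2)C1=O`, is not yet measured. It keeps the ethyl of compound 2 but changes the aryl group on the ring nitrogen: 4-fluorophenyl in place of 2-methylphenyl on an amine nitrogen in a ring.

Among the compounds with values here, one measured step bears on this: no change at the digits printed from compound 1 to compound 3 (within the scatter), where fluoro replaced methyl on an aromatic carbon without moving the number. Within the data shown here, that exchange kept the group name otherwise the same, whereas here 2-methylphenyl gives way to 4-fluorophenyl, a change no measured pair tests directly. Taking the fluoro-for-methyl result as the nearest guide, compound 4 is expected to show no change at the digits printed from compound 2 to compound 4 (within the scatter), that is, nothing beyond the scatter. The estimate for compound 4 is therefore 100 mg/kg, with a range from 50 mg/kg to 300 mg/kg.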

Compound 4, minimum effective dose: 100 mg/kg
Compound 4: the middle estimate sits on the measured number at the digits printed; the measured number falls inside the stated range.
By their numbers in this assay, from the lowest: compounds 2 and 4 (each within the scatter of the next); then compounds 1 and 3 (each within the scatter of the next).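

With the ethyl-bearing core of compound 2 held fixed in this assay, exchanging the aryl group on the amine nitrogen in a ring gives no change at the digits printed from compound 2 to compound 4 (within the scatter). The earlier step, no change at the digits printed from compound 1 to compound 3 (within the scatter), tested only fluoro in place of methyl on an aromatic carbon in compounds without the ethyl, so this result adds that 4-fluorophenyl can take the place of 2-methylphenyl on the ethyl-bearing core while the number stays where compound 2 put it. Nothing shown here explains why the number holds through this exchange.

From the compounds shown here alone, whether an unsubstituted phenyl, a 4-chlorophenyl or a 4-methoxyphenyl on the same nitrogen would give the same number remains open, so two aryl groups are too few to define what this position accepts. Also open, going by these compounds, is what a longer chain such as propyl in place of the ethyl would do to the number, and whether an amine or a carboxylic acid on the aromatic ring would leave it unchanged.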